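A 4-chlorophenyl swap on an aromatic nitrogen

The source may report more compounds than this note shows. Statements on the series, on what has been measured and on what is new or still open speak of the compounds shown alone.

In a functional assay on MCF7 cells (Homo sapiens) for inhibition, read by MTT assay, with a stated time of 72 h (on this read-out higher numbers stand for weaker inhibition and lower numbers for stronger inhibition), compound 1 `Cc1cccc(-n2c(-c3coc4cc(C)c(Cl)cc4c3=O)nc(-c3ccccc3)c2-c2ccccc2)c1` gives 12500 nM and compound 2 `Cc1ccc(-n2c(-c3coc4cc(C)c(Cl)cc4c3=O)nc(-c3ccccc3)c2-c2ccccc2)c(C)c1` gives 6250 nM. Among the compounds with values here, the only measured step, a 2.0-fold lower number from compound 1 to compound 2 (0.30 log units; within the scatter), lies within the scatter, so compound 2 cannot be ranked apart from its single neighbour. Compound 3 `Cc1cc2occ(-c3nc(-c4ccccc4)c(-c4ccccc4)n3-c3ccc(Cl)cc3)c(=O)c2cc1Cl` brings a new change: 4-chlorophenyl in place of 2,4-dimethylphenyl on an aromatic nitrogen. That is 4-chlorophenyl in place of 2,4-dimethylphenyl on an aromatic nitrogen. Within the data shown here, no chlorinated group at this place has been measured, so the small step above is the only guide, and no change beyond the scatter is expected in this assay. The expected step is a 1.1-fold higher number from compound 2 to compound 3 (0.05 log units; within the scatter). For compound 3 the estimated value is 7000 nM, within a range of 2500 nM to 20000 nM.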

Compound 3, half-maximal inhibitory concentration: 12500 nM
For compound 3 the middle estimate is 1.8-fold (0.25 log units) below the measured one; measured number inside the range.
By their numbers in this assay, from the lowest: compounds 2, 1 and 3 (each within the scatter of the next).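

In this assay, a chlorinated group on the aromatic nitrogen reads the same, within the scatter, as either methylated one: 4-chlorophenyl against 2,4-dimethylphenyl (a 2.0-fold higher number from compound 2 to compound 3 (0.30 log units; within the scatter)), and 4-chlorophenyl against 3-methylphenyl (no change at the digits printed from compound 1 to compound 3 (within the scatter)). Across these three compounds, then, exchanging these substituted phenyl groups at this position gives no difference that can be read. Nothing available here offers an explanation for this. Still open, going by these compounds, is how an amine or a carboxylic acid on this phenyl ring would read, and whether a longer chain could replace the ring altogether.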